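The compounds below may be only part of what the source reports. "The series", "measured", "known", "first", "only" and "open" are said of these compounds alone.

Compound 1 `CC(C)(C)C1=C(C(=O)O)N2C(=O)[C@H]([C@H](O)CCc3ccccc3)[C@H]2O1`: 21 h. Compound 2 `CC(C)(C)C1=C(C(=O)O)N2C(=O)[C@H]([C@H](O)CCc3ccc(O)cc3)[C@H]2O1`: 24.6 h. Compound 3 `CC(C)(C)C1=C(C(=O)O)N2C(=O)[C@H]([C@@H](O)c3ccccc3)[C@H]2O1`: 8.9 h.

All three were read in an ADME assay, in phosphate buffer, at 28 degrees C, at pH 7.0; on this read-out lower numbers stand for a shorter-lived compound and higher numbers for a longer-lived compound. Compound 1 and compound 2 differ only by hydroxy in place of hydrogen on an aromatic carbon, and that step is a 1.2-fold higher number from compound 1 to compound 2 (0.07 log units; within the scatter). The core of compound 3 differs from the core of compound 1, but the difference between the two cores is not broken down here; in this assay compound 3 gives the lowest of the three numbers, with compound 1 the nearest above it. Compound 4 `CC(C)(C)C1=C(C(=O)O)N2C(=O)[C@H]([C@@H](O)c3ccc(O)cc3)[C@H]2O1` has not yet been measured. It differs from compound 3 by hydroxy in place of hydrogen on an aromatic carbon, the same change as that from compound 1 to compound 2. Since that earlier step was a 1.2-fold higher number from compound 1 to compound 2 (0.07 log units; within the scatter), a similar step is expected here: a 1.1-fold higher number from compound 3 to compound 4 (0.05 log units; within the scatter). Compound 4 is therefore estimated at 10 h, most likely between 6 h and 17 h.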

Compound 4, half-life: 10.3 h
The estimate for compound 4 lay 1.0-fold (0.01 log units) below the measured number; the range from low to high includes it.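

In this assay, hydroxy in place of hydrogen on an aromatic carbon gives a 1.2-fold higher number from compound 3 to compound 4 (0.06 log units; within the scatter). Set beside the earlier step, the change carries over from one core to the other with no difference that can be told apart: the same change on two cores in this assay, a 1.2-fold higher number (0.07 log units; within the scatter) from compound 1 to compound 2 and a 1.2-fold higher number (0.06 log units; within the scatter) from compound 3 to compound 4, 1.0-fold (0.01 log units) apart, within the scatter of two such steps. This shows that the two steps agree on these two cores, but both lie within the scatter, and two pairs do not show that the change would behave alike on any other core in the series.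

The compounds shown leave open whether a methoxy group, an amine or a carboxylic acid in place of the hydroxy would give a similar step. Also open, from the compounds shown here alone, is whether the step would hold on a core with a longer chain.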